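A few compounds are considered here, and "the series" means these few. Any claim that something is new, unique, unknown or untested is made for them only; others in the source may bear on it.

Measured compounds:
- compound 1 `O=C(NNc1c(Br)cccc1Br)c1ccc(Br)cc1`, in a toxicity assay on MDCK cells (Canis lupus familiaris) for cytotoxicity, read by CCK-8 assay, with a stated time of 48 h; a higher number here means that more compound is tolerated, a lower number that less compound is tolerated: > 100000 nM, a limit of the assay, not a number
- compound 2 `O=C(NNc1c(Br)cccc1Br)c1ccccc1`, in this assay: > 100000 nM, likewise a limit
- compound 3 `CCOc1ccc(C(=O)NNc2c(Br)cc(Br)cc2Br)cc1`, in this assay: 54800 nM, the only number in the set

Compound 1 and compound 2 differ by hydrogen in place of bromo on an aromatic carbon. For the measured compounds named here, the step between them in this assay, a step that the two limits leave unreadable from compound 1 to compound 2, cannot be read, since both values are limits; the only evidence bearing on it is the limit of > 100000 nM in this assay, at which 2 of the 3 values shown sit.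

Compound 3 carries a different core from compound 1; the difference between the two cores is not broken down here. Compound 4 `CCOc1ccc(C(=O)NNc2ccc(Br)cc2Br)cc1` is not yet measured in this assay. It differs from compound 3 by hydrogen in place of bromo on an aromatic carbon. This is the same kind of change as from compound 1 to compound 2, but not the same: in compound 1 the bromo that leaves sits para to a large group, whereas in compound 3 it sits ortho to a large group and meta to two bromo groups.

Going by the values given here, because the measured step that the two limits leave unreadable from compound 1 to compound 2 is unreadable, there is no numeric precedent for the size of this change in this assay. The expectation for compound 4 therefore rests on the value of compound 3, 54800 nM. It also rests on the fact that two of three compounds sit at the limit of > 100000 nM in this assay, at which 2 of the 3 values shown sit. The step from compound 3 to compound 4 is estimated as a 1.5-fold higher number from compound 3 to compound 4 (0.16 log units; within the scatter), a small move that stays within the usual scatter. Compound 4 is expected to give about 80000 nM in this assay, with a plausible range from 30000 nM to 200000 nM.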

Compound 4, half-maximal cytotoxic concentration: > 100000 nM
Compound 4 was reported as a limit (the forecaster's own chance of this, stated with the estimate: 40%); middle value at least 1.2-fold (0.09 log units) from the limit.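

In this assay, hydrogen in place of bromo on the core of compound 3 gives an at least 1.8-fold higher number from compound 3 to compound 4 (0.26 log units; that floor lies within the scatter); this is a floor and not a measured size, and because it lies within the scatter, it does not by itself establish a real move. For the compounds shown here, the same kind of change on the core of compound 1 cannot be read, since both values there are limits, and the bromo that leaves compound 3, ortho to a large group and meta to two bromo groups, stands at a different place from the one that leaves compound 1, so the two cases give no size to compare and no measure of how well the change carries from one core to the other. The pair therefore shows only that the change on the core of compound 3 ends at a limit, and neither core gives a number for it, because the read-outs stop there: the limit of > 100000 nM in this assay, at which 3 of the 4 values shown sit.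

Still open, on these data alone, is how far the number of compound 4 lies from that of compound 3, and whether any compound with fewer bromo groups falls back into the readable range. Also open, as far as these compounds go, is how compound 3 would stand in this assay with an amine, a carboxylic acid or a longer chain in place of its ethoxy group.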